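A few compounds are considered here, and "the series" means these few. Any claim that something is new, unique, unknown or untested is made for them only; others in the source may bear on it.

Within the data shown here, in a functional assay on cells (T-cell, Homo sapiens) for inhibition, read by scintillation counting and thymidine incorporation, with stated times of 60 min and 3 days (on this read-out lower numbers stand for stronger inhibition and higher numbers for weaker inhibition), compound 1 `COc1ccc(-c2cc3c(N[C@H](CO)[C@@H](C)O)c(C(N)=O)cnn3c2)cn1` gives 370 nM and compound 2 `C[C@@H](O)[C@@H](CO)Nc1c(C(N)=O)cnn2cc(-c3ccccc3)cc12` gives 70 nM as the lowest number so far. The full change to compound 3 `C[C@H](O)[C@H](CO)Nc1c(C(N)=O)cnn2cc(-c3ccccc3)cc12` reads: the two compounds have the same atoms and bonds and differ only in configuration as drawn: 2 of 2 stereo elements differ (all stereocentres are inverted: mirror images); a stereocentre at a saturated chain carbon is drawn R in compound 2 and S in compound 3; a stereocentre at a saturated chain carbon is drawn R in compound 2 and S in compound 3 and no more. Among the measured compounds shown here, no measured step inverts a stereocentre. For the measured compounds named here, the only step, a 5.3-fold lower number from compound 1 to compound 2 (0.72 log units; beyond the scatter) for phenyl in place of 6-methoxypyridin-3-yl, lies elsewhere on the molecule and gives only a scale. A shift of similar or somewhat larger size toward a higher number is expected in this assay on that scale. The expected step is an 8.6-fold higher number from compound 2 to compound 3 (0.93 log units; beyond the scatter) as a rough guess. For compound 3 the estimated value is 600 nM within a range of 120 nM to 3000 nM here.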

Compound 3, half-maximal inhibitory concentration: 2000 nM
Compound 3: the middle estimate sits 3.3-fold (0.52 log units) below what was measured; the range from low to high includes it.
By their numbers in this assay, from the lowest: compound 2; then compound 1; then compound 3.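

Configuration at the two saturated chain carbons carries real weight in this series: a 29-fold higher number from compound 2 to compound 3 (1.46 log units; beyond the scatter). Compound 1 and compound 2 share one configuration, so they could not show this. The shift belongs to configuration alone, because nothing else separates the pair: the fact that compounds 2 and 3 differ only in the configuration as drawn.

The compounds shown leave open which of the two stereocentres accounts for the step, as both change together here. Also open, on these data alone, is whether a longer chain, or an amine in place of a chain hydroxyl, would keep this dependence on configuration.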